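Isopropyl for Methyl in a Series at the Limit

The compounds below may be only part of what the source reports. "The series", "measured", "known", "first", "only" and "open" are said of these compounds alone.

Compound 1 is `Cc1ccc(C(=O)Nc2nc(Cl)c3cn(C)nc3n2)cc1`. In a functional assay on CHO cells for antagonist activity at adenosine receptor A2b (Homo sapiens), read by 33P incorporation, with a stated time of 20 min, in the presence of a further agent that is not named here (a higher number here means a weaker inhibitor, a lower number a stronger inhibitor), compound 1 gives only the limit > 20000 nM.
Compound 2 is `Cn1cc2c(Cl)nc(NC(=O)c3ccc(C(F)(F)F)cc3)nc2n1`. In this assay compound 2 likewise gives only the limit > 20000 nM.
Compound 3 is `Cn1cc2c(Cl)nc(NC(=O)c3ccc(F)cc3)nc2n1`. In this assay compound 3 also gives only the limit > 20000 nM.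

Compound 2 thus stands exactly where every measured value stands: at a limit, not a number (the limit of > 20000 nM in this assay, at which 3 of the 3 values shown sit). The steps among the measured compounds, a step that the two limits leave unreadable from compound 1 to compound 2, a step that the two limits leave unreadable from compound 1 to compound 3 and a step that the two limits leave unreadable from compound 2 to compound 3, cannot be read, since both ends of each sit at that limit.

Compound 4 is `CC(C)n1cc2c(Cl)nc(NC(=O)c3ccc(C(F)(F)F)cc3)nc2n1`. The change from compound 2 is isopropyl in place of methyl on an aromatic nitrogen. Among the measured compounds shown here, none of the measured steps involves the group on that aromatic nitrogen, so no step bears directly on this change; all that bears on it is that compound 2 itself is reported only as a limit.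

The step from compound 2 to compound 4 in this assay is expected to be a step that the limit leaves unreadable from compound 2 to compound 4, with no direction readable from the data. Compound 4 is therefore estimated at 25000 nM, between 6000 nM and 100000 nM, and is expected most likely to be reported again only as a limit.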

Compound 4, inhibition constant: > 20000 nM
Compound 4: no number, only a limit (the forecaster's own chance of this, stated with the estimate: 80%); the middle value lies beyond the limit too.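

Compound 4 also gives only a limit, so the step from compound 2 to compound 4, isopropyl in place of methyl, cannot be read: the limit of > 20000 nM in this assay, at which 4 of the 4 values shown sit.

The compounds shown leave open how strongly any of them acts in this assay, and whether any group on the shared core gives a readable number.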